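The source may hold more compounds than are shown below. What is called first, only, known or untested is meant among the compounds shown, and "the series" means these compounds.

Measured in a functional assay on HT-29 cells (Homo sapiens) for inhibition, with a stated time of 72 h; a lower number here means a stronger inhibitor, a higher number a weaker inhibitor:
- compound 1 `COc1cc(C(=O)n2ccc3ccccc32)cc(OC)c1OC`: 9600 nM
- compound 2 `COc1cc(C(=O)c2cccc3[nH]ccc23)cc(OC)c1OC`: 46.4 nM
- compound 3 `COc1cc(C(=O)c2ccc3cc[nH]c3c2)cc(OC)c1OC`: 330 nM

Compound 2 stands lowest of the three, and its gaps to both others lie beyond the scatter. Compound 4 `COc1cc(C(=O)c2cccc3c2ccn3C)cc(OC)c1OC` has methyl in place of hydrogen on an aromatic nitrogen of compound 2 (methyl in place of hydrogen on an aromatic nitrogen). Within the data shown here, no measured pair shows this change, so the expectation rests on the structures alone: a modest rise in this assay, possibly none beyond the scatter. The measured values spread widely, with compound 1 at 9600 nM, and this calls for a broad range. The expected change is a 1.5-fold higher number from compound 2 to compound 4 (0.18 log units; within the scatter). For compound 4 the estimated value is 70 nM, with an expected range of 20 nM to 300 nM.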

Compound 4, half-maximal inhibitory concentration: 22.4 nM
Compound 4: the middle estimate sits 3.1-fold (0.49 log units) above what was measured; the measured number falls inside the stated range.
By their numbers in this assay, from the lowest: compound 4; then compound 2; then compound 3; then compound 1.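

Methyl in place of hydrogen on the aromatic nitrogen brings a 2.1-fold lower number from compound 2 to compound 4 (0.32 log units; beyond the scatter) in this assay, a modest step but the first read at this position. It shows that the hydrogen on this nitrogen is not needed for inhibition in this assay, and that this place accepts a methyl group without loss. Nothing at hand accounts for the step.

On these data alone, whether ethyl, a longer chain or a chain ending in an amine would hold this level on the same nitrogen stays open. So does whether methyl would act alike on the nitrogen of compound 3 .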